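Adding a benzyl group to compound 3

The compounds below may be only part of what the source reports. "The series", "measured", "known", "first", "only" and "open" are said of these compounds alone.

Values measured so far in a functional assay on MCF7 cells (Homo sapiens) for antiproliferative activity, read by MTT assay, with a stated time of 72 h (a higher number here means a weaker inhibitor, a lower number a stronger inhibitor), are:
- compound 1 `COc1ccc(NC(=S)Nc2nc(C(=O)NCc3ccccc3)cs2)cc1` gives 24600 nM
- compound 2 `O=C(NCCCc1ccccc1)c1csc(NC(=S)Nc2ccc(Cl)cc2)n1` gives 45100 nM
- compound 3 `CCOC(=O)c1csc2nc(CN3CCN(C)CC3)c(-c3ccc(C)cc3)n12` gives 58300 nM

Compound 3 (58300 nM) stands within the scatter of compound 2 (45100 nM), and the two share the upper end of these numbers. Compound 1 (24600 nM) has a lower number, beyond the scatter from compound 3.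

Compound 4 `CCOC(=O)c1csc2nc(CN3CCN(Cc4ccccc4)CC3)c(-c3ccc(C)cc3)n12` differs from compound 3 by phenyl in place of hydrogen on a saturated chain carbon bound to an amine nitrogen in a ring in one place: phenyl in place of hydrogen on a saturated chain carbon bound to an amine nitrogen in a ring, so that methyl becomes benzyl. Among the measured compounds shown here, no two measured compounds differ in one place, so the data do not size this change. In this assay a small move toward a lower number is expected, of about the size of the scatter. The expected change is a 1.7-fold lower number from compound 3 to compound 4 (0.22 log units; within the scatter) as estimated here. Compound 4 is estimated at 35000 nM with an expected range from 12000 nM to 80000 nM in this series.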

Compound 4, half-maximal inhibitory concentration: 29100 nM
The estimate for compound 4 lay 1.2-fold (0.08 log units) above the measured number, and the stated range covers the measured number.
By their numbers in this assay, from the lowest: compounds 1, 4, 2 and 3 (each within the scatter of the next, the first and the last beyond it).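

Methyl to benzyl on the amine nitrogen in the ring gives the first one-place comparison in the series: in this assay, it reads a 2.0-fold lower number from compound 3 to compound 4 (0.30 log units; within the scatter). At this position, a phenyl with its 6 heavy atoms can therefore enter without a shift beyond the scatter, so the compound 3 side chain does not depend on keeping the small methyl group for this antiproliferative reading. No measurement here bears on why the step has this size.

The compounds shown leave open whether a longer chain, such as phenethyl, or a more polar substituent, such as hydroxyethyl, in place of benzyl would move the number beyond the scatter. They also leave open whether methyl to benzyl gives a similar step on another core.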